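A few compounds are considered here, and "the series" means these few. Any claim that something is new, unique, unknown or untested is made for them only; others in the source may bear on it.

Measured in a functional assay on SK-OV-3 cells (Homo sapiens) for inhibition; on this read-out higher numbers stand for weaker inhibition and lower numbers for stronger inhibition:
- compound 1 `CCOC(=O)Nc1nc(=O)n(C2O[C@H](C(=O)O)[C@@H](O)[C@H]2O)cc1F`: 0.16 ug/mL
- compound 2 `C=CCOC(=O)Nc1nc(=O)n(C2O[C@H](C(=O)O)[C@@H](O)[C@H]2O)cc1F`: 0.008 ug/mL
- compound 3 `O=C(Nc1nc(=O)n(C2O[C@H](C(=O)O)[C@@H](O)[C@H]2O)cc1F)Oc1ccccc1`: 0.12 ug/mL

Compound 1 stands at the upper end of these numbers. Its closest neighbour shows a 1.3-fold lower number from compound 1 to compound 3 (0.12 log units; within the scatter), and its furthest shows a 20-fold lower number from compound 1 to compound 2 (1.30 log units; beyond the scatter).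

Compound 4 `O=C(Nc1nc(=O)n(C2O[C@H](C(=O)O)[C@@H](O)[C@H]2O)cc1F)OCc1ccccc1` is still unmeasured. The change is phenyl in place of methyl on a saturated chain carbon bound to an oxygen next to a carbonyl group, or ethyl to benzyl when cut one bond further out.

Two kinds of evidence bear on it. Among the measured compounds shown here, the only step at this same place is a 20-fold lower number from compound 1 to compound 2 (1.30 log units; beyond the scatter), so a large drop is possible there. Phenyl directly on the oxygen gives a much smaller change, with a 1.3-fold lower number from compound 1 to compound 3 (0.12 log units; within the scatter) and a 15-fold higher number from compound 2 to compound 3 (1.18 log units; beyond the scatter). Compound 4 shares features with both, and three compounds cannot settle which precedent applies, so a moderate step to a lower number is expected in this assay. The expected step is a 3.2-fold lower number from compound 1 to compound 4 (0.51 log units; beyond the scatter). Compound 4 is estimated at 0.05 ug/mL, with an expected range of 0.012 ug/mL to 0.2 ug/mL.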

Compound 4, half-maximal inhibitory concentration: 0.07 ug/mL
Estimate against measurement, compound 4: 1.4-fold (0.15 log units) below; low and high end bracket the measured number.
By their numbers in this assay, from the lowest: compound 2; then compounds 4, 3 and 1 (each within the scatter of the next, the first and the last beyond it).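

In this assay, ethyl to benzyl on the oxygen next to a carbonyl group gives a real but modest step (a 2.3-fold lower number from compound 1 to compound 4 (0.36 log units; beyond the scatter)), so a phenyl on the saturated chain carbon is tolerated and changes the number beyond the scatter. Compound 3 and compound 4 cannot be told apart (a 1.7-fold lower number from compound 3 to compound 4 (0.23 log units; within the scatter)), so phenyl and benzyl on that oxygen read the same here. The allyl group of compound 2 stays apart from the benzyl group (an 8.8-fold higher number from compound 2 to compound 4 (0.94 log units; beyond the scatter)), and compound 2 is now beyond the scatter from all three other compounds.

Going by these compounds, whether the gain in compound 2 depends on its vinyl end stays open, and a propyl chain at this place would separate that from chain length alone. No measurement shown here accounts for these differences.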